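The source may hold more compounds than are shown below. What is called first, only, known or untested is meant among the compounds shown, and "the series" means these compounds.

Of the compounds shown here, three sharing one core have been measured in a functional assay on MCF7 cells (Homo sapiens) for inhibition, read by MTT assay, with a stated time of 24 h; on this read-out higher numbers stand for weaker inhibition and lower numbers for stronger inhibition. Compound 1 `CCOC(=O)C1=Cc2ccccc2OC1(OCc1cn(-c2ccc(F)cc2)nn1)C(F)(F)F` carries a 4-fluorophenyl group on the aromatic nitrogen of the triazole, and in this assay compound 1 gives 9100 nM. Compound 2 `CCCCCCCCn1cc(COC2(C(F)(F)F)Oc3ccccc3C=C2C(=O)OCC)nn1` carries an octyl chain at the same place; its value in this assay, > 150000 nM, is a limit of the assay and not a number. Compound 3 `CCOC(=O)C1=Cc2ccccc2OC1(OCc1cn(CC(=O)Nc2ccccc2Br)nn1)C(F)(F)F` carries a ((2-bromophenyl)carbamoyl)methyl group there; its value in this assay, > 150000 nM, is likewise only a limit, so compound 3 stands at the weak end of the series, which is where the limit of > 150000 nM in this assay, at which 2 of the 3 values shown sit, places two of the three values. The two readable steps both leave compound 1: an at least 16-fold higher number from compound 1 to compound 2 (1.21 log units; beyond the scatter) and an at least 16-fold higher number from compound 1 to compound 3 (1.21 log units; beyond the scatter), while the step between compound 2 and compound 3 cannot be read from two limits.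

Compound 4 `CCOC(=O)C1=Cc2ccccc2OC1(OCc1cn(-c2ccc(F)c([N+](=O)[O-])c2)nn1)C(F)(F)F` is not yet measured. It differs from compound 3 by 4-fluoro-3-nitrophenyl in place of ((2-bromophenyl)carbamoyl)methyl on an aromatic nitrogen. This returns the aryl substituent on the triazole nitrogen that compound 1 bears, now with a nitro group added. Compound 3 itself reached only a limit in this assay. Since the aryl-bearing compound 1 gave 9100 nM in this assay, a large fall in this assay is expected, an at least 15-fold lower number from compound 3 to compound 4 (1.17 log units; beyond the scatter). Compound 4 is therefore estimated at 10000 nM, between 3000 nM and 40000 nM.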

Compound 4, half-maximal inhibitory concentration: 16200 nM
Estimate against measurement, compound 4: 1.6-fold (0.21 log units) below, and the stated range covers the measured number.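

With 4-fluoro-3-nitrophenyl on the aromatic nitrogen, a second aryl group gives a readable number in this assay, which sets it apart from both substituents that reached the limit: an at least 9.2-fold lower number from compound 3 to compound 4 (0.96 log units; beyond the scatter) and an at least 9.2-fold lower number from compound 2 to compound 4 (0.96 log units; beyond the scatter). The nitro group in place of hydrogen on an aromatic carbon leaves no readable difference, a 1.8-fold higher number from compound 1 to compound 4 (0.25 log units; within the scatter), so compound 1 and compound 4 stand level and this aromatic carbon tolerates the nitro group in this assay. Among the four compounds, the 4-fluorophenyl and 4-fluoro-3-nitrophenyl groups give numbers, whereas the octyl group of compound 2 and the ((2-bromophenyl)carbamoyl)methyl group of compound 3 both end at a limit, not a number: the limit of > 150000 nM in this assay, at which 2 of the 4 values shown sit.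

The compounds shown do not fix the true size of the steps from compound 2 and compound 3, whose values are limits. They also leave open whether an amine or a carboxylic acid in place of the nitro group, or a shorter chain such as butyl in place of octyl, would give a readable number at this position.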